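A Nitrile in Place of a Nitro Group

A few compounds are considered here, and "the series" means these few. Any claim that something is new, unique, unknown or untested is made for them only; others in the source may bear on it.

Compound 1 `CNC(=O)c1cc(Oc2ccc(C(=O)/C=C/c3cccc([N+](=O)[O-])c3)cc2)ccn1` carries a 3-nitrophenyl group at one end of a double-bonded chain. In a functional assay on MCF7 cells (Homo sapiens) for cytotoxicity, read by MTT assay, with a stated time of 72 h (on this read-out lower numbers stand for stronger inhibition and higher numbers for weaker inhibition), compound 1 gives only a limit, > 50000 nM, so no number is known for it; this is the limit of > 50000 nM in this assay, at which 1 of the 2 values shown sits. Compound 2 `CNC(=O)c1cc(Oc2ccc(C(=O)/C=C/c3cc(OC)c(OC)c(OC)c3)cc2)ccn1` shares the core of compound 1. In this assay compound 2 gives 3880 nM. Compound 3 `CNC(=O)c1cc(Oc2ccc(C(=O)/C=C/c3ccc(C#N)cc3)cc2)ccn1` differs from compound 1 in one place: 4-cyanophenyl in place of 3-nitrophenyl on a double-bonded chain carbon bound to a double-bonded chain carbon. For the measured compounds named here, no step between two measured compounds covers this change, so the expectation rests only on the two values above. A gain in this assay that clears the usual scatter is thought possible because compound 2 reaches 3880 nM with a different group at the same place. The step from compound 1 to compound 3 is expected to be an at least 2.0-fold lower number from compound 1 to compound 3 (0.30 log units; that floor lies within the scatter). Compound 3 is estimated at about 25000 nM in this assay, within 5000 nM to 60000 nM.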

Compound 3, half-maximal inhibitory concentration: 9520 nM
Compound 3: the middle estimate sits 2.6-fold (0.42 log units) above what was measured; measured number inside the range.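

In this assay, for the compounds shown here, putting 4-cyanophenyl in place of 3-nitrophenyl on a double-bonded chain carbon bound to a double-bonded chain carbon gives an at least 5.2-fold lower number from compound 1 to compound 3 (0.72 log units; beyond the scatter), the first step at this position that can be read. It shows that this one change at the end of the chain is enough to turn a compound with no measurable number into one with a measured number, while the shared core stays the same. Going by these compounds, the true size of the step remains unknown, because compound 1 gives only a limit and not a number: the limit of > 50000 nM in this assay, at which 1 of the 3 values shown sits.

The group and its place on the phenyl ring change together here, so the compounds shown cannot tell which of the two matters. On these data alone, how an amine or a carboxylic acid at this same place would read also stays open.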